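Taking one methoxy off compound 2

The source may hold more compounds than are shown below. What is called first, only, known or untested is meant among the compounds shown, and "the series" means these compounds.

compound 1 `CCCCCCCCC(=O)NCc1ccccc1OC`: > 100000 nM
compound 2 `CCCCCCCCC(=O)NCc1cc(OC)c(O)cc1OC`: > 100000 nM

Both compounds were tested in a functional assay with Rattus norvegicus as the target; on this read-out lower numbers stand for an effect already at smaller amounts and higher numbers for an effect only at larger amounts of compound. In this assay compound 1 gives > 100000 nM, which is a limit and not a number. Compound 2 gives > 100000 nM, which is also a limit and not a number. Compound 2 therefore has no exact position on the scale, and the measurements so far show only (the limit of > 100000 nM in this assay, at which 2 of the 2 values shown sit).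

Compound 3 `CCCCCCCCC(=O)NCc1ccc(O)cc1OC` differs from compound 2 in one place, where hydrogen stands in place of methoxy on an aromatic carbon (hydrogen in place of methoxy on an aromatic carbon). That carbon is ortho to a hydroxy group and para to a methoxy group, and the rest of the molecule stays the same.

Going by the values given here, no measured pair shows what such a change does in this assay, so the expectation starts from compound 2 at > 100000 nM. No change beyond the usual scatter is expected, and this assay may well report only a limit again. If a number does appear, a slightly lower one is more likely. The expected move is an at least 1.4-fold lower number from compound 2 to compound 3 (0.15 log units; that floor lies within the scatter). For compound 3 the estimate is 70000 nM, with an expected range from 10000 nM to 200000 nM.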

Compound 3, half-maximal effective concentration: > 100000 nM
Compound 3: a limit, no number; the forecaster's own chance of this, stated with the estimate: 65%; middle value at least 1.4-fold (0.15 log units) away from the limit.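

In this assay compound 3 also gives a limit and not a number, as compound 1 and compound 2 do, so the steps from compound 1 and compound 2 to compound 3 cannot be read: the limit of > 100000 nM in this assay, at which 3 of the 3 values shown sit.

The compounds shown leave open how far any of them lies from that limit, and what swapping hydrogen for methoxy or hydroxy on the aromatic carbon does to the read-out.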